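The compounds below may be only part of what the source reports. "The series", "measured", "known", "first", "only" and "open" are said of these compounds alone.

Compound 1 `Cc1ccc2c(C3CCN(CCN4CCNC4=O)CC3)cn(-c3ccc(F)cc3)c2c1` serves as the reference point. In an assay on cell membranes for displacement of a labelled ligand from Adrenergic receptor alpha-1 (Rattus norvegicus) (on this read-out lower numbers stand for stronger inhibition and higher numbers for weaker inhibition), compound 1 gives 24 nM. Two other compounds share its core and differ from it in a single aromatic substituent: compound 2 `O=C1NCCN1CCN1CCC(c2cn(-c3ccc(F)cc3)c3cc(C(F)(F)F)ccc23)CC1` gives 33 nM in this assay, and compound 3 `O=C1NCCN1CCN1CCC(c2cn(-c3ccc(F)cc3)c3cc(F)ccc23)CC1` gives 2.2 nM. Placed among these numbers, compound 1 shows a 1.4-fold higher number from compound 1 to compound 2 (0.14 log units; within the scatter) and an 11-fold lower number from compound 1 to compound 3 (1.04 log units; beyond the scatter), while a 15-fold lower number from compound 2 to compound 3 (1.18 log units; beyond the scatter) completes the set.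

Compound 4 `Cc1ccc2c(C3CCN(CCNC(=O)NC(C)C)CC3)cn(-c3ccc(F)cc3)c2c1` has not yet been measured. Its difference from compound 1 is (isopropylcarbamoyl)amino in place of 2-oxoimidazolidin-1-yl on a saturated chain carbon, two bonds along the chain from an amine nitrogen in a ring. Going by the values given here, none of the measured steps touches this part of the molecule; all three concern the aromatic carbon, and only the two that bring in fluoro there are large. They therefore offer no direct guide to a change at the chain carbon, and the expectation for compound 4 must be wide and centred close to compound 1. Compound 4 is expected to give 50 nM in this assay, within a range from 10 nM to 250 nM, which would amount to a 2.1-fold higher number from compound 1 to compound 4 (0.32 log units; beyond the scatter).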

Compound 4, half-maximal inhibitory concentration: 76 nM
Compound 4: the middle estimate sits 1.5-fold (0.18 log units) below what was measured; the measured number falls inside the stated range.
By their numbers in this assay, from the lowest: compound 3; then compounds 1 and 2 (each within the scatter of the next); then compound 4.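

The position on the saturated chain carbon is not silent: in this assay, replacing 2-oxoimidazolidin-1-yl with (isopropylcarbamoyl)amino gives a 3.2-fold higher number from compound 1 to compound 4 (0.50 log units; beyond the scatter) and the step is modest. The ring of the leaving group is therefore not needed for a measurable reading, as compound 4 carries no ring at this place and still gives 76 nM in the same assay. Nothing available here explains why the number moves in this direction.

The change removes the ring and brings in the isopropyl group in a single step, so the compounds shown leave open which of the two accounts for the shift. They also leave open whether an amine, a carboxylic acid or a longer chain would be accepted at this place, and whether the step would hold with the fluoro group of compound 3 on the aromatic carbon.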